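The source may hold more compounds than are shown below. What is called first, only, known or untested is meant among the compounds shown, and "the series" means these compounds.

Compound 1 `N#C/N=C1\N(CCCCCOc2ccc(Cl)cc2)C(=O)C(c2ccccc2)N1c1ccncc1` gives 415 nM in a functional assay on HepG2 cells (Homo sapiens) for cytotoxicity; on this read-out lower numbers stand for stronger inhibition and higher numbers for weaker inhibition. Compound 2 `N#C/N=C1\N(CCCCCCOc2ccc(Cl)cc2)C(=O)C(c2ccccc2)N1c1ccncc1` gives 44 nM. Compound 3 `N#C/N=C1\N(CCCCCOc2ccc(Cl)cc2)C(=O)CCN1c1ccncc1` gives 2830 nM.

From compound 1 to compound 2 the change is (4-chlorophenoxy)methyl in place of 4-chlorophenoxy on a saturated chain carbon, five bonds along the chain from an amide-type nitrogen in a ring, and it made a 9.4-fold lower number from compound 1 to compound 2 (0.97 log units; beyond the scatter). Compound 3 shares the pyridyl-bearing ring system of compound 1 but lacks the phenyl substituent on it; the difference between the two cores is not broken down here. Compound 4 `N#C/N=C1\N(CCCCCCOc2ccc(Cl)cc2)C(=O)CCN1c1ccncc1` carries the same change relative to compound 3, namely ((4-chlorophenoxy)methyl in place of 4-chlorophenoxy on a saturated chain carbon, five bonds along the chain from an amide-type nitrogen in a ring), at the same place. Within the data shown here, the only guide to its size is the single earlier step, so compound 4 is expected to give 450 nM, between 120 nM and 1700 nM. That estimate means an expected step of a 6.3-fold lower number from compound 3 to compound 4 (0.80 log units; beyond the scatter), assumed somewhat smaller than the one seen from compound 1 to compound 2 because compound 3 gives 2830 nM as the only number for its core, which has shown no step of its own.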

Compound 4, half-maximal inhibitory concentration: 344 nM
For compound 4 the middle estimate is 1.3-fold (0.12 log units) above the measured one; the measured number falls inside the stated range.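

In this assay, putting (4-chlorophenoxy)methyl in place of 4-chlorophenoxy gave an 8.2-fold lower number from compound 3 to compound 4 (0.92 log units; beyond the scatter), so the change also lowered the number on the core without the phenyl substituent. Set beside the earlier step, the two agree in size: the same change on two cores in this assay, a 9.4-fold lower number (0.97 log units; beyond the scatter) from compound 1 to compound 2 and an 8.2-fold lower number (0.92 log units; beyond the scatter) from compound 3 to compound 4, 1.1-fold (0.06 log units) apart, within the scatter of two such steps. Among these compounds, this shows that the change carried over between these two cores, but it rests on only one pair of cores and does not show why the steps match or whether the same step would appear on any other core.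

The compounds shown leave open whether a longer chain would lower the number further. They also leave open how an amine or a carboxylic acid in place of 4-chlorophenoxy would behave on either core.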